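Swapping the triazole side arm and what it means for cell toxicity

The source may report more compounds than this note shows. Statements on the series, on what has been measured and on what is new or still open speak of the compounds shown alone.

Measured so far in an ADME assay on MT4 cells (Homo sapiens) for cytotoxicity, read by MTT assay, with a stated time of 5 days; on this read-out lower numbers stand for higher toxicity in this test and higher numbers for lower toxicity in this test:
- compound 1, `Cc1cc(C)c(Oc2cc(Nc3ccc(C#N)cc3)ncc2C(=O)NCc2cn(CC(N)=O)nn2)c(C)c1`: 24000 nM
- compound 2, `Cc1cc(C)c(Oc2cc(Nc3ccc(C#N)cc3)ncc2C(=O)NCc2cn(CCC#N)nn2)c(C)c1`: 40200 nM
- compound 3, `Cc1cc(C)c(Oc2cc(Nc3ccc(C#N)cc3)ncc2C(=O)NCc2cn(CC(=O)N3CCOCC3)nn2)c(C)c1`: 181000 nM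

Compound 3 has the highest number of the three, so it is the least toxic to these cells. Compound 1 and compound 2 sit close together, as the change a 1.7-fold higher number from compound 1 to compound 2 (0.22 log units; within the scatter) shows. The two steps that reach compound 3, a 7.5-fold higher number from compound 1 to compound 3 (0.88 log units; beyond the scatter) and a 4.5-fold higher number from compound 2 to compound 3 (0.65 log units; beyond the scatter), are the only ones that move beyond the scatter, and both gain their size by bringing in the (morpholin-4-yl)carbonyl group.

Compound 4, `Cc1cc(C)c(Oc2cc(Nc3ccc(C#N)cc3)ncc2C(=O)NCc2cn(Cc3cccc([N+](=O)[O-])c3)nn2)c(C)c1`, takes that group away again: 3-nitrophenyl in place of (morpholin-4-yl)carbonyl on a saturated chain carbon bound to an aromatic nitrogen. Going by the values given here, nothing among the measured compounds carries an aromatic ring at this place, so the nitrophenyl part is new ground. Among the compounds with values here, what the data do show is that the only steps beyond the scatter, a 7.5-fold higher number from compound 1 to compound 3 (0.88 log units; beyond the scatter) and a 4.5-fold higher number from compound 2 to compound 3 (0.65 log units; beyond the scatter), are the ones in which the (morpholin-4-yl)carbonyl group enters; with that group gone, the number is expected to fall back, placing compound 4 near compound 1 and compound 2 rather than near compound 3. Within the data shown here, a drop of roughly a 6.0-fold lower number from compound 3 to compound 4 (0.78 log units; beyond the scatter) is therefore expected, with wide uncertainty because the entering ring has no precedent here.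

Compound 4 is estimated at 30000 nM in this assay, within a range from 9000 nM to 100000 nM.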

Compound 4, half-maximal cytotoxic concentration: >= 156000 nM
Compound 4 ended at the assay's limit; the forecaster's own chance of this, stated with the estimate: 10%; middle value at least 5.2-fold (0.71 log units) away from the limit.
By their numbers in this assay, from the lowest: compounds 1 and 2 (each within the scatter of the next); then compound 3.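

Compound 4 stands at a limit of this assay rather than at a true number: the limit of >= 156000 nM in this assay, at which 1 of the 4 values shown sits. Going by these compounds alone, the (morpholin-4-yl)carbonyl group is therefore not the only group at this place, on a saturated chain carbon bound to an aromatic nitrogen, that goes with a high number and so with lower toxicity in this test: 3-nitrophenyl, whose six-membered aromatic ring holds carbon only, gives an at least 3.8-fold higher number from compound 2 to compound 4 (0.58 log units; beyond the scatter) and an at least 6.5-fold higher number from compound 1 to compound 4 (0.81 log units; beyond the scatter). The step between compound 3 and compound 4 cannot be read, so these two compounds cannot be put in order, and a non-aromatic ring and an aromatic one can only be said to share a high reading here.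

As far as these compounds go, it remains open whether the aromatic ring or the nitro group goes with the high reading, a question that a plain phenyl group, or a phenyl group bearing an amine or a carboxylic acid in place of the nitro group, would help to settle. Also open, from the compounds shown here alone, is whether a longer chain carrying the same 3-nitrophenyl group would keep the reading this high.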